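The source may report more compounds than this note shows. Statements on the series, on what has been measured and on what is new or still open speak of the compounds shown alone.

Compound 3 `CNC(=O)c1cc(C(=O)NC2CC2)cn([C@H](C)c2ccccc2)c1=O` gives 815 ug/mL in a physicochemical assay for solubility, read by HPLC, in simulated intestinal fluid, with a stated time of 16 h, tested at 125 ug/mL (a lower number here means a less soluble compound, a higher number a more soluble compound), the highest of the three numbers shown, though compound 1 `CNC(=O)c1cc(C(=O)NC2CC2)cn(Cc2cccc(OC)c2)c1=O` with 582 ug/mL lies within the scatter of it, while compound 2 `CNC(=O)c1cc(C(=O)NC2CC2)cn(Cc2cccc3cc[nH]c23)c1=O` with 11 ug/mL is far below. Compound 4 `CNC(=O)c1cc(C(=O)NC2CC2)cn(Cc2ccc(F)cc2)c1=O` differs from compound 3 in one place: 4-fluorobenzyl in place of 1-phenylethyl on an aromatic nitrogen. Among the measured compounds shown here, no measured step matches this change. For the measured compounds named here, the only step recorded, a 53-fold lower number from compound 1 to compound 2 (1.72 log units; beyond the scatter), concerns a different exchange of aromatic groups at the same position; compound 1 and compound 3, which carry two different groups there, do not differ beyond the scatter. For compound 4 a step of a 1.4-fold lower number from compound 3 to compound 4 (0.13 log units; within the scatter) is therefore expected, nothing beyond the scatter. Compound 4 is estimated at 600 ug/mL, within 300 ug/mL to 1000 ug/mL.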

Compound 4, solubility: 84 ug/mL
The estimate for compound 4 lay 7.1-fold (0.85 log units) above the measured number, and the stated range ends above it.
By their numbers in this assay, from the lowest: compound 2; then compound 4; then compounds 1 and 3 (each within the scatter of the next).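

In this assay, the group on the aromatic nitrogen matters beyond the 1H-indol-7-yl exchange: 4-fluorobenzyl in place of 1-phenylethyl gives a 9.7-fold lower number from compound 3 to compound 4 (0.99 log units; beyond the scatter) and 4-fluorophenyl in place of 3-methoxyphenyl gives a 6.9-fold lower number from compound 1 to compound 4 (0.84 log units; beyond the scatter) on the saturated chain carbon. Yet 4-fluorophenyl in place of 1H-indol-7-yl gives a 7.6-fold higher number from compound 2 to compound 4 (0.88 log units; beyond the scatter) in the opposite direction, so these groups spread widely. No measurement shown here accounts for these steps.

The step from 1-phenylethyl changes both the chain methyl and the ring fluorine, and the compounds shown cannot separate the two. Where a plain benzyl group would fall remains open.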